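Dimethylphenyl in Place of Aminophenyl: One Estimated Step

This account rests on a few compounds, and the source may have more. Where it says the series, first, only, none or still open, it means among the compounds named here.

Measured so far in a functional assay on HepG2 cells (Homo sapiens) for antiproliferative activity, read by MTT assay, with a stated time of 48 h; on this read-out lower numbers stand for stronger inhibition and higher numbers for weaker inhibition:
compound 1 `COc1ccc(/C=C/c2cc(OC)cc(OC)c2/C=C/C(=O)c2ccc(N)cc2)cc1` gives 7.5 ug/mL;
compound 2 `CCCC(C)Oc1ccc(C(=O)/C=C/c2c(/C=C/c3ccc(OC)cc3)cc(OC)cc2OC)cc1` gives 11.1 ug/mL;
compound 3 `COc1ccc(/C=C/c2cc(OC)cc(OC)c2/C=C/C(=O)c2ccc(C(F)(F)F)cc2)cc1` gives 18.7 ug/mL.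

Compound 1 shows the lowest number of the three, though its step to compound 2 stays within the scatter and only its step to compound 3 goes beyond it. Compound 4 `COc1ccc(/C=C/c2cc(OC)cc(OC)c2/C=C/C(=O)c2ccc(C)cc2C)cc1` differs from compound 1 in one place: 2,4-dimethylphenyl in place of 4-aminophenyl on a carbonyl carbon. Both measured steps that remove the amino group bear on this change: a 1.5-fold higher number from compound 1 to compound 2 (0.17 log units; within the scatter) and a 2.5-fold higher number from compound 1 to compound 3 (0.40 log units; beyond the scatter) each gave a higher number, one within the scatter and one modestly beyond. A rise of similar size is therefore expected for compound 4, as a 1.9-fold higher number from compound 1 to compound 4 (0.27 log units; within the scatter). Compound 4 is estimated at 14 ug/mL, with a range from 7 ug/mL to 30 ug/mL.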

Compound 4, half-maximal inhibitory concentration: 0.9 ug/mL
Beside the measured number, compound 4's estimate is 16-fold (1.19 log units) above it; measured number outside the range, below it.
By their numbers in this assay, from the lowest: compound 4; then compounds 1, 2 and 3 (each within the scatter of the next, the first and the last beyond it).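

Swapping in 2,4-dimethylphenyl on this carbonyl carbon brought an 8.3-fold lower number from compound 1 to compound 4 (0.92 log units; beyond the scatter) and a 12-fold lower number from compound 2 to compound 4 (1.09 log units; beyond the scatter) and a 21-fold lower number from compound 3 to compound 4 (1.32 log units; beyond the scatter) in this assay for the compounds shown. Losing the amino group therefore need not raise the number, as the earlier steps alone might suggest, and what replaces it matters greatly. No measurement here explains the drop.

Compound 4 carries two methyl groups, and the compounds shown leave open whether one alone would do. Going by these compounds, whether ethyl or methoxy groups on the same ring would give a similar number also remains open.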